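This account rests on a few compounds, and the source may have more. Where it says the series, first, only, none or still open, it means among the compounds named here.

Measured compounds and values:
- compound 1 `CCS(=O)(=O)Nc1cc(-c2ccc3ncnc(Nc4ccc(OC)cc4)c3c2)cnc1OC`: 1880 nM
- compound 2 `CCS(=O)(=O)Nc1cc(-c2ccc3ncnc(Nc4ccc(OCc5ccc(F)cc5)c(Cl)c4)c3c2)cnc1OC`: 14600 nM
- compound 3 `CCCCS(=O)(=O)Nc1cc(-c2ccc3ncnc(Nc4cccc(C(=O)OCC)c4)c3c2)cnc1OC`: 37200 nM

Three compounds of the series have been run in a functional assay on BT-549 cells (Homo sapiens) for cytotoxicity, read by sulforhodamine B assay, with a stated time of 72 h; on this read-out higher numbers stand for weaker inhibition and lower numbers for stronger inhibition. Compound 1 gives the lowest number of the three; compound 2 and compound 3 both give higher numbers, and each of those gaps lies beyond the scatter of this assay. All three share the same core, and they differ from one another in more than one place, so no single-change comparison between measured compounds is available.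

Compound 4 `CCS(=O)(=O)Nc1cc(-c2ccc3ncnc(Nc4ccc(OC)nc4)c3c2)cnc1OC` is the next compound to be measured. It differs from compound 1 in one place only: 6-methoxypyridin-3-yl in place of 4-methoxyphenyl on a nitrogen on an aromatic ring. For the measured compounds named here, no measured pair in this set isolates such a change, so there is no direct precedent. The expectation is that the step of a 1.3-fold higher number from compound 1 to compound 4 (0.12 log units; within the scatter) stays within the scatter or moves modestly toward a higher number. Compound 4 is therefore estimated at 2500 nM in this assay, with a range of 900 nM to 7000 nM.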

Compound 4, half-maximal inhibitory concentration: 3490 nM
Compound 4: middle estimate off by 1.4-fold (0.14 log units), on the low side; the measured number falls inside the stated range.
By their numbers in this assay, from the lowest: compounds 1 and 4 (each within the scatter of the next); then compound 2; then compound 3.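

In this assay, 6-methoxypyridin-3-yl in place of 4-methoxyphenyl on the nitrogen gives a 1.9-fold higher number from compound 1 to compound 4 (0.27 log units; within the scatter), the first single-change comparison available in the series. This position therefore accepts a ring nitrogen, and with it a second hydrogen-bond acceptor by count, with no change in cytotoxicity that this read-out can resolve. No accompanying measurement bears on this step, so the result describes the outcome of the exchange and does not explain it.

Still open, on these data alone, is whether an amine or a longer ethoxy chain in place of the methoxy on the new ring would keep the number within the same scatter. Also open, as far as these compounds go, is whether the same exchange of rings gives a similar step when made on the other compounds.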